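The source may report more compounds than this note shows. Statements on the series, on what has been measured and on what is new or still open speak of the compounds shown alone.

Measured so far:
- compound 1, `CC[C@@H](Nc1c(C#N)c(-c2ccc(-c3ncccc3C)cc2)nc2cnccc12)C(N)=O`, 2
- compound 2, `CCOc1ccccc1-c1ccc(-c2nc3cnccc3c(C[C@H](C)C(=O)O)c2C#N)cc1`, 2.2
- compound 3, `CC[C@@H](Nc1c(C#N)c(-c2ccc(Br)cc2)nc2cnccc12)C(=O)O`, 1.6

These three compounds share a core and were all measured in a physicochemical assay for lipophilicity, read by HPLC, at pH 7.5; a higher number here means a more lipophilic compound, a lower number a more polar compound. Compound 1 gives 2, the second highest of the three numbers. Compound 2 gives 2.2, which lies within the scatter of compound 1, so the two cannot be told apart. Compound 3 gives 1.6, lower than compound 1 by more than the scatter.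

Compound 4, `CC[C@@H](Nc1c(C#N)c(-c2ccc(-c3ccccc3F)cc2)nc2cnccc12)C(N)=O`, has not yet been measured. Compared with compound 1 it differs in one place: 2-fluorophenyl in place of 3-methylpyridin-2-yl on an aromatic carbon. The ring that leaves holds one hetero atom and one hydrogen-bond acceptor; the ring that enters is carbon only with a fluorine and no hydrogen-bond acceptor. Among the measured compounds shown here, no pair among the measured compounds shows this exact change, so its size must be guessed.

Starting from compound 1 at 2, compound 4 is expected to give a higher number, with an estimated step of a number 1.00 log units higher from compound 1 to compound 4 (beyond the scatter), clearly beyond the scatter. The estimate for compound 4 is 3, between 2.5 and 3.5.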

Compound 4, distribution coefficient: 2.7
The estimate for compound 4 lay 0.30 log units above the measured number; the range from low to high includes it.
By their numbers in this assay, from the lowest: compound 3; then compounds 1 and 2 (each within the scatter of the next); then compound 4.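

In this assay, among the compounds shown here, exchanging one ring for another, para to a large group, gives a number 0.70 log units higher from compound 1 to compound 4 (beyond the scatter) as the first comparison here of compounds that differ in one place. It shows that this position registers a change of ring, even though both rings have the same number of heavy atoms: the ring that leaves holds a nitrogen and a hydrogen-bond acceptor, while the ring that enters is carbon only and carries a fluorine. No measurement here explains the step.

With the nitrogen, methyl and fluorine all changing together, this single step cannot assign the difference to any one of them; 2-methylphenyl at this position would separate them in part. On these data alone, how an amine or a longer chain on this ring would read also remains open.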